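The source may report more compounds than this note shows. Statements on the series, on what has been measured and on what is new or still open speak of the compounds shown alone.

Measured so far:
- compound 1 `COc1ccc(/C=C/C=C/C=C/C(=O)N2CCCCC2)cc1`: 1.08%
- compound 2 `O=C(/C=C/C=C/c1ccc(OC2CCCC2)cc1)N1CCCCC1`: 16.1%
- compound 3 `COc1cc(/C=C/C=C/C(=O)N2CCCCC2)cc(OC)c1O`: 32.7%

In an assay for inhibition of Polyunsaturated fatty acid 5-lipoxygenase (Homo sapiens), read by spectrophotometry, tested at 20 uM (on this read-out lower numbers stand for less inhibition and higher numbers for more inhibition at the one concentration tested (going by the name of the read-out)), compound 2 stands second of the three, with compound 1 giving a lower number and compound 3 a higher one, both differences beyond the scatter. Compound 4 `CN(C)c1ccc(/C=C/C=C/C(=O)N2CCCCC2)cc1` differs from compound 2 by one change: dimethylamino in place of cyclopentyloxy on an aromatic carbon. Among the compounds with values here, no pair among the measured compounds shows a step of this kind, so the size of the step can only be guessed. The expectation is a small fall in this assay, not clearly beyond the scatter, since compound 2 gives a low number to start from. Compound 4 is expected to give about 12%, with a range from 0% to 30%, which means a step of a number 4.1 percentage points lower from compound 2 to compound 4 (within the scatter).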

Compound 4, a percentage reported as inhibition, at one concentration (the size of the read-out at that concentration, not a potency): 13.4%
Estimate against measurement, compound 4: 1.4 percentage points below; low and high end bracket the measured number.
By their numbers in this assay, from the lowest: compound 1; then compounds 4 and 2 (each within the scatter of the next); then compound 3.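

In this assay the series gains its first comparison in one place, a number 2.7 percentage points lower from compound 2 to compound 4 (within the scatter), on an aromatic carbon para to a large group. Dimethylamino in place of cyclopentyloxy thus removes the five-membered non-aromatic ring without a change beyond the scatter, and the hydrogen-bond acceptor and donor counts stay the same. No measured evidence bears on this step. Steps to compound 1 and compound 3 cannot be read, since each differs from compound 2 in more than one place. Open at this position are a primary amine, a carboxylic acid and a longer alkoxy chain.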